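Fluoropropoxy in place of fluorobenzyloxy at the aryl ether

This account rests on a few compounds, and the source may have more. Where it says the series, first, only, none or still open, it means among the compounds named here.

Measured compounds:
compound 1, `c1ccc(COc2cccc(-c3cn([C@@H]4CN5CCC4CC5)nn3)c2)cc1`, 414 nM in an assay on HEK293 cells for displacement of a labelled ligand from Neuronal acetylcholine receptor; alpha4/beta2 (Homo sapiens), read by scintillation counting, with a stated time of 120 min; on this read-out higher numbers stand for weaker inhibition and lower numbers for stronger inhibition
compound 2, `Fc1ccc(COc2cccc(-c3cn([C@@H]4CN5CCC4CC5)nn3)c2)cc1`, 537 nM

Among the compounds with values here, compound 2 stands at the higher of the two numbers so far, with compound 1 as its only neighbour; the step of a 1.3-fold higher number from compound 1 to compound 2 (0.11 log units; within the scatter) is within the scatter, so the two compounds cannot be ranked against each other on this read-out.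

Compound 3, `FCCCOc1cccc(-c2cn([C@@H]3CN4CCC3CC4)nn2)c1`, has not yet been measured. It differs from compound 2 in one place: 2-fluoroethyl in place of 4-fluorophenyl on a saturated chain carbon bound to an oxygen on an aromatic ring. Within the data shown here, the one measured step, a 1.3-fold higher number from compound 1 to compound 2 (0.11 log units; within the scatter), concerns only a fluoro in place of hydrogen on the aromatic ring and says nothing about removing that ring altogether, so no measured step bears directly on this change. With nothing to anchor it, the account can only expect that the loss of the ring is more likely to raise the number than lower it, and the size is uncertain.

For compound 3 in this assay the estimate is 1000 nM, with a range from 250 nM to 4000 nM. The step this implies, a 1.9-fold higher number from compound 2 to compound 3 (0.27 log units; within the scatter), is expected with low confidence.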

Compound 3, inhibition constant: 1980 nM
Estimate against measurement, compound 3: 2.0-fold (0.30 log units) below, within the range that was stated.
By their numbers in this assay, from the lowest: compounds 1 and 2 (each within the scatter of the next); then compound 3.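

In this assay, 2-fluoroethyl in place of 4-fluorophenyl on a saturated chain carbon bound to an oxygen on an aromatic ring gives a 3.7-fold higher number from compound 2 to compound 3 (0.57 log units; beyond the scatter), and 2-fluoroethyl in place of phenyl at the same place gives a 4.8-fold higher number from compound 1 to compound 3 (0.68 log units; beyond the scatter). The fluoro on the aromatic ring had made no readable difference, but exchanging the whole ring for this shorter chain does move the number beyond the scatter, although only modestly, so that (4-fluorobenzyl)oxy and benzyloxy both stand at lower numbers than 3-fluoropropoxy, with compound 3 at 1980 nM. No measured information on why the number rises with this exchange is available.

These compounds change the aromatic ring and the size of the group together, so they leave open whether the ring itself or simply the bulk of the group sets the number. A cyclohexylmethoxy group, a plain propoxy group or a longer chain such as hexyloxy at this place would begin to separate the ring, the chain length and the chain fluorine.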